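From methoxy to chloro at the assay limit

The source may report more compounds than this note shows. Statements on the series, on what has been measured and on what is new or still open speak of the compounds shown alone.

Compound 1 `COc1cccc(-c2ncnn2-c2cc(OC)c(OC)c(OC)c2)c1` value > 10000 nM
Compound 2 `COc1cc(-c2ncnn2-c2ccc(Cl)cc2)cc(OC)c1OC` value > 10000 nM

In a functional assay on A549 cells (Homo sapiens) for antiproliferative activity, read by MTT assay, with a stated time of 72 h (a higher number here means a weaker inhibitor, a lower number a stronger inhibitor), compound 1 stands at > 10000 nM as a limit of the assay, not a number. Compound 2 at > 10000 nM is also a limit. Among the measured compounds shown here, the whole picture so far is the limit of > 10000 nM in this assay, at which 2 of the 2 values shown sit, and no measured step exists.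

Compound 3 (`COc1cc(-n2ncnc2-c2cccc(Cl)c2)cc(OC)c1OC`) carries 3-chlorophenyl in place of the 3-methoxyphenyl of compound 1 (chloro in place of methoxy on an aromatic carbon). With compound 1 at > 10000 nM as a limit, no step beyond the scatter is expected in this assay and another limit is likely. The expected change is a step that the limit leaves unreadable from compound 1 to compound 3 as an estimate only. For compound 3 the estimated value is 12000 nM (expected range 4000 nM to 30000 nM).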

Compound 3, half-maximal inhibitory concentration: > 10000 nM
Compound 3: a limit, no number; the forecaster's own chance of this, stated with the estimate: 75%; the middle value lies beyond the limit too.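

Compound 1 and compound 3 both stand at a limit of the assay rather than at a number, so no step can be read between them: the limit of > 10000 nM in this assay, at which 3 of the 3 values shown sit.

The compounds shown leave open whether swapping methoxy for chloro changes activity at all, since none of them gives a readable value.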